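Methyl to cyclopropyl on the linking carbon of the biaryl series

A few compounds are considered here, and "the series" means these few. Any claim that something is new, unique, unknown or untested is made for them only; others in the source may bear on it.

Of the compounds shown here, two have been measured in an in vitro assay on V79MZh cells for inhibition of cytochrome P450 11B2, mitochondrial (Homo sapiens); a lower number here means a stronger inhibitor, a higher number a weaker inhibitor. Compound 1, `CC(c1ccc(-c2ccccc2)nc1)n1ccnc1`, gives 200 nM. Compound 2, `CC(c1ccc(-c2cccc3ccccc23)nc1)n1ccnc1`, carries a larger aromatic group on the core and gives 273 nM. Only these two numbers are known, and they lie within the usual scatter of each other, so nothing can be said about whether the larger aromatic group changes the read-out.

Compound 3, `c1ccc2c(-c3ccc(C(C4CC4)n4ccnc4)cn3)cccc2c1`, keeps the core and the aromatic group of compound 2 and differs from it in one place: cyclopropyl in place of methyl on a saturated chain carbon bound to an aromatic carbon and an aromatic nitrogen. For the measured compounds named here, no pair of measured compounds shows the effect of this change, so the step has to be judged from the change itself. A small group is exchanged for a somewhat larger saturated ring at the carbon that joins the two aromatic parts, and no evidence in the series points to a direction.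

The step in this assay from compound 2 to compound 3 is expected to be a 1.1-fold lower number from compound 2 to compound 3 (0.04 log units; within the scatter), not beyond the scatter. For compound 3 the half-maximal inhibitory concentration is estimated at 250 nM, within 80 nM to 800 nM.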

Compound 3, half-maximal inhibitory concentration: 220 nM
Compound 3: the middle estimate sits 1.1-fold (0.06 log units) above what was measured; the measured number falls inside the stated range.
By their numbers in this assay, from the lowest: compounds 1, 3 and 2 (each within the scatter of the next).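

In this assay, for the compounds shown here, cyclopropyl in place of methyl on a saturated chain carbon bound to an aromatic carbon and an aromatic nitrogen gives a 1.2-fold lower number from compound 2 to compound 3 (0.09 log units; within the scatter), the first reading of this change. With the core and aromatic group of compound 2, this position therefore takes the three-membered ring of 3 heavy atoms in place of the 1 heavy atom of methyl with no difference beyond the scatter. No measurement at hand offers an explanation for this result.

Still open, on these data alone, is how a longer chain, a cyclohexyl ring, an amine or a carboxylic acid on this carbon would read in this assay. Also open, as far as these compounds go, is whether cyclopropyl in place of methyl reads the same with the aromatic group of compound 1, since this single step on one aromatic group supports no general rule for the series.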